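The source may report more compounds than this note shows. Statements on the series, on what has been measured and on what is new or still open speak of the compounds shown alone.

Of the compounds shown here, three sharing one core have been measured in a functional assay on NCI-H1581 cells (Homo sapiens) for antiproliferative activity, read by CCK-8 assay, with a stated time of 72 h; a higher number here means a weaker inhibitor, a lower number a stronger inhibitor. Compound 1 `CCN1CCN(c2ccc(C(=O)Nc3n[nH]c4nc(-c5c(Cl)c(OC)cc(OC)c5Cl)ccc34)cc2)CC1` gives 0.7 nM, compound 2 `COc1cc(OC)c(Cl)c(-c2ccc3c(NC(=O)c4ccc(N5CCN(C(C)C)CC5)cc4)n[nH]c3n2)c1Cl` gives 1.4 nM, and compound 3 `C=CCN1CCN(c2ccc(C(=O)Nc3n[nH]c4nc(-c5c(Cl)c(OC)cc(OC)c5Cl)ccc34)cc2)CC1` gives 3.3 nM. Compound 3 therefore has the highest number of the three and is the weakest inhibitor of the set, though all three values remain low.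

The next compound, compound 4 `COc1cc(OC)c(Cl)c(-c2ccc3c(NC(=O)c4ccccc4)n[nH]c3n2)c1Cl`, departs from compound 3 far more than these three differ from each other. The change is hydrogen in place of 4-allylpiperazin-1-yl on an aromatic carbon.

The measured steps bear on this only indirectly, since each alters just the substituent on an amine nitrogen in the ring. The step of a 2.0-fold higher number from compound 1 to compound 2 (0.30 log units; within the scatter) lies within the scatter, while a 4.7-fold higher number from compound 1 to compound 3 (0.67 log units; beyond the scatter) and a 2.4-fold higher number from compound 2 to compound 3 (0.37 log units; beyond the scatter) are modest. None of the three compounds lacks the ring, so the data do not show directly what its loss does in this assay.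

Even so, a change of this size is expected to exceed those modest steps and to raise the number beyond the scatter. The expected step is a 12-fold higher number from compound 3 to compound 4 (1.08 log units; beyond the scatter), and this size is an estimate with wide uncertainty. For compound 4 the estimated value is 40 nM, with an expected range from 8 nM to 250 nM.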

Compound 4, half-maximal inhibitory concentration: > 1000 nM
Compound 4: no number, only a limit (the forecaster's own chance of this, stated with the estimate: 5%); middle value at least 25-fold (1.39 log units) from the limit.
By their numbers in this assay, from the lowest: compounds 1 and 2 (each within the scatter of the next); then compound 3. At a limit, above all of these: compound 4.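

Compound 4 gives no number in this assay, only a limit: the limit of > 1000 nM in this assay, at which 1 of the 4 values shown sits.

Among these compounds, measured against that limit, the steps are an at least 300-fold higher number from compound 3 to compound 4 (2.48 log units; beyond the scatter), an at least 710-fold higher number from compound 2 to compound 4 (2.85 log units; beyond the scatter) and an at least 1400-fold higher number from compound 1 to compound 4 (3.15 log units; beyond the scatter), all large and all greater than the biggest step among the earlier compounds, a 4.7-fold higher number from compound 1 to compound 3 (0.67 log units; beyond the scatter). The earlier compounds shown here showed only that exchanging ethyl, isopropyl and allyl on the ring nitrogen moves the number little or modestly, whereas compound 4 shows that this position, on an aromatic carbon para to a large group, is far from indifferent, since hydrogen in place of the whole group brings a large loss.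

The compounds shown carry either a complete piperazine-based group or hydrogen at this position, so they leave open which part of that group matters. From the compounds shown here alone, whether a morpholine ring, an open-chain amine or a piperazine with a free ring nitrogen would keep the number low remains unanswered, and the true size of the loss also stays open, as compound 4 has only a limit.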